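The compounds below may be only part of what the source reports. "The series", "measured", "known", "first", "only" and "open" are said of these compounds alone.

Measured compounds:
compound 1 `CNC(=O)c1cc(C(=O)NC2CC2)cn([C@H](C)c2ccccc2)c1=O` with 3.4 in a physicochemical assay for lipophilicity, at pH 7.4; on this read-out higher numbers stand for higher lipophilicity and lower numbers for lower lipophilicity
compound 2 `CNC(=O)c1cc(C(=O)NCC(C)C)cn(Cc2ccccc2)c1=O` with 4.3 in this assay
compound 3 `CNC(=O)c1cc(C(=O)NC2CC2)cn(Cc2cccc(C)c2)c1=O` with 3.6 in this assay

Compound 3 stands second highest of the three numbers in this assay; its nearest neighbour is compound 1, lower by a step that is within the scatter, and its furthest is compound 2, higher by a gap beyond the scatter. Compound 4 `CNC(=O)c1cc(C(=O)NC2CC2)cn(Cc2cccc3occc23)c1=O` has not yet been measured. It differs from compound 3 in one place: 1-benzofuran-4-yl in place of 3-methylphenyl on a saturated chain carbon bound to an aromatic nitrogen. Among the measured compounds shown here, the only single-place step among the measured compounds, a number 0.20 log units higher from compound 1 to compound 3 (within the scatter), concerns a different exchange and so gives no direct guide. With nothing in the data pointing either way, compound 4 is expected to stay close to compound 3, with a step of about no change at the digits printed from compound 3 to compound 4 (within the scatter). Compound 4 is therefore estimated at 3.6, in the range 3.2 to 4.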

Compound 4, distribution coefficient: 3.4
Compound 4: the middle estimate sits 0.20 log units above what was measured, and the stated range covers the measured number.
By their numbers in this assay, from the lowest: compounds 1, 4 and 3 (each within the scatter of the next); then compound 2.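

In this assay the exchange of 3-methylphenyl for 1-benzofuran-4-yl on a saturated chain carbon bound to an aromatic nitrogen gives a number 0.20 log units lower from compound 3 to compound 4 (within the scatter), so this place accepts a larger group with a five-membered aromatic ring and a hydrogen-bond acceptor without a step beyond the scatter. The earlier compounds shown here carried only carbon-only aromatic rings here and could not show this. No measurement at hand accounts for the size of this step. Still open, on these data alone, is whether an amine or a carboxylic acid at this place would also stay within the scatter of compound 3.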